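Swapping 4-nitrobenzyl for 3-fluorobenzyl on the shared core

The source may hold more compounds than are shown below. What is called first, only, known or untested is meant among the compounds shown, and "the series" means these compounds.

In a functional assay on HepG2 cells (Homo sapiens) for antiproliferative activity, read by MTT assay, with a stated time of 24 h (a lower number here means a stronger inhibitor, a higher number a weaker inhibitor), compound 1 `COc1cc(OC)c(-c2coc3cc(OCc4ccc(F)cc4)ccc3c2=O)cc1OC` gives 1000 nM while compound 2 `COc1cc(OC)c(-c2coc3cc(OCc4ccc([N+](=O)[O-])cc4)ccc3c2=O)cc1OC` gives 2500 nM as the higher of the two numbers, so compound 2 is the weaker inhibitor of this pair. Compound 3 `COc1cc(OC)c(-c2coc3cc(OCc4cccc(F)c4)ccc3c2=O)cc1OC` has not yet been measured. It differs from compound 2 in one place 3-fluorophenyl in place of 4-nitrophenyl on a saturated chain carbon bound to an oxygen on an aromatic ring with 3-fluorophenyl in place of 4-nitrophenyl on a saturated chain carbon bound to an oxygen on an aromatic ring. For the measured compounds named here, the one measured step that bears on this, nitro in place of fluoro on an aromatic carbon, gives a 2.5-fold higher number from compound 1 to compound 2 (0.40 log units; beyond the scatter) as a modest change. Going by the values given here, compound 3 carries its fluoro at a different place from compound 1, and no measurement yet shows what that difference does. A modest fall is therefore expected in this assay with an estimated 2.1-fold lower number from compound 2 to compound 3 (0.32 log units; beyond the scatter) as the likely step. The estimate for compound 3 is 1200 nM with an expected range of 500 nM to 2900 nM for now.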

Compound 3, half-maximal inhibitory concentration: 1230 nM
Beside the measured number, compound 3's estimate is 1.0-fold (0.01 log units) below it; the measured number falls inside the stated range.
By their numbers in this assay, from the lowest: compounds 1 and 3 (each within the scatter of the next); then compound 2.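

In this assay moving the fluoro, with 3-fluorophenyl in place of 4-fluorophenyl, gives a 1.2-fold higher number from compound 1 to compound 3 (0.09 log units; within the scatter) and so shows no readable effect of where the fluoro sits in this pair. For the compounds shown here, replacing 4-nitrophenyl with 3-fluorophenyl gives a 2.0-fold lower number from compound 2 to compound 3 (0.31 log units; beyond the scatter) and leaves compound 2, the only nitro compound, as the weakest of the three, with both fluoro compounds reading alike. No measurement at hand explains these numbers.

From the compounds shown here alone, what remains open is how a plain benzyl with nothing on its ring, a 4-methoxybenzyl or a 4-aminobenzyl would compare on the shared core. Also open, going by these compounds, is whether 3-nitrobenzyl would differ from 4-nitrobenzyl, or whether a longer chain between the oxygen and the ring would change the reading.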